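The compounds below may be only part of what the source reports. "The series", "measured", "known", "first", "only" and "open" are said of these compounds alone.

Measured compounds:
- compound 2 `COc1c(OCCCN2CCN(C)CC2)cc(O)c2c(=O)cc(-c3ccccc3)oc12`: 9900 nM
- compound 1 `CN(C)CCCCOc1c(O)cc(O)c2c(=O)cc(-c3ccccc3)oc12`: > 100000 nM (a limit)
- compound 3 `COc1c(O)cc(O)c2c(=O)cc(-c3ccc(F)cc3Br)oc12`: "not determined" (no result reported)

Among the measured compounds shown here, in a functional assay on A549 cells (Homo sapiens) for cytotoxicity, read by MTT assay, with a stated time of 48 h (on this read-out higher numbers stand for weaker inhibition and lower numbers for stronger inhibition), compound 2 gives 9900 nM, the only number among the three entries. For compound 1 this assay records only a limit, > 100000 nM (the limit of > 100000 nM in this assay, at which 1 of the 3 values shown sits). Compound 3 carries no result in this assay.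

Compound 4 `COc1c(OCCCCN2CCNCC2)cc(O)c2c(=O)cc(-c3ccccc3)oc12` is not yet measured. It differs from compound 2 in one place: (piperazin-1-yl)methyl in place of 4-methylpiperazin-1-yl on a saturated chain carbon, three bonds along the chain from an oxygen on an aromatic ring. For the measured compounds named here, no measured pair in this set shows such a change, so no step size is known for it. The step from compound 2 to compound 4 is expected to stay within the usual scatter, with no clear direction: a 1.0-fold higher number from compound 2 to compound 4 (0.00 log units; within the scatter). Compound 4 is therefore estimated at 10000 nM, between 4000 nM and 30000 nM.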

Compound 4, half-maximal inhibitory concentration: 1740 nM
For compound 4 the middle estimate is 5.7-fold (0.76 log units) above the measured one, outside the stated range (below it).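

Among the compounds shown here, this is the first readable step at this position in this assay: replacing 4-methylpiperazin-1-yl with (piperazin-1-yl)methyl on the saturated chain carbon gives a 5.7-fold lower number from compound 2 to compound 4 (0.76 log units; beyond the scatter). The same difference reads as 3-(4-methylpiperazin-1-yl)propyl to 4-(piperazin-1-yl)butyl, so the side chain here responds to a rearrangement that leaves the atoms unchanged. Nothing in the available evidence bears on the reason for this step.

The compounds shown do not separate the longer chain from the loss of the methyl group on nitrogen. As far as these compounds go, how a 4-(4-methylpiperazin-1-yl)butyl or a 3-(piperazin-1-yl)propyl chain would behave remains open.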